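A few compounds are considered here, and "the series" means these few. Any claim that something is new, unique, unknown or untested is made for them only; others in the source may bear on it.

Compound 1 `CSCC(=O)N1CCN(c2nc(=O)c3cc(C(F)(F)F)cc([N+](=O)[O-])c3s2)CC1` in a physicochemical assay for solubility, read by HPLC (a higher number here means a more soluble compound, a lower number a less soluble compound), gives 15.2 ug/mL as its number.
Compound 2 `O=C(C1CCCCC1)N1CCN(c2nc(=O)c3cc(C(F)(F)F)cc([N+](=O)[O-])c3s2)CC1` in this assay gives 3.24 ug/mL as its number.
Compound 3 `O=C(c1cccc(F)c1)N1CCN(c2nc(=O)c3cc(C(F)(F)F)cc([N+](=O)[O-])c3s2)CC1` in this assay gives 0.2 ug/mL as its number.

Compound 2 stands second highest of the three numbers in this assay: the step of a 4.7-fold lower number from compound 1 to compound 2 (0.67 log units; beyond the scatter) puts compound 1 above it, and the step of a 16-fold lower number from compound 2 to compound 3 (1.21 log units; beyond the scatter) puts compound 3 below it, while the step of a 76-fold lower number from compound 1 to compound 3 (1.88 log units; beyond the scatter) spans the whole set. Compound 4 `CC(C)(C)C1CCC(C(=O)N2CCN(c3nc(=O)c4cc(C(F)(F)F)cc([N+](=O)[O-])c4s3)CC2)CC1` differs from compound 2 by tert-butyl in place of hydrogen on a saturated ring carbon. Among the compounds with values here, no measured step touches the cyclohexyl ring itself, so none bears directly on this change; the two steps that replace the group on the carbonyl carbon, the modest 4.7-fold lower number from compound 1 to compound 2 (0.67 log units; beyond the scatter) and the large 16-fold lower number from compound 2 to compound 3 (1.21 log units; beyond the scatter), both went to lower numbers, and the cyclohexyl ring of compound 2 already sits below compound 1. On that basis a modest step downward in this assay is expected, smaller than the step to compound 3. Compound 4 is therefore estimated at 0.8 ug/mL, with a range from 0.2 ug/mL to 3 ug/mL, an expected step of a 4.1-fold lower number from compound 2 to compound 4 (0.61 log units; beyond the scatter).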

Compound 4, solubility: < 0.1 ug/mL
Compound 4 ended at the assay's limit; the forecaster's own chance of this, stated with the estimate: 10%; middle value at least 8.0-fold (0.90 log units) from the limit.
By their numbers in this assay, from the lowest: compound 3; then compound 2; then compound 1. At a limit, below all of these: compound 4.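

In this assay, compound 4 stands at a limit and not at a number: the limit of < 0.1 ug/mL in this assay, at which 1 of the 4 values shown sits. The earlier steps shown here each replaced the whole group on the carbonyl carbon, whereas this change keeps the cyclohexyl ring and puts tert-butyl in place of hydrogen on a saturated ring carbon, three ring bonds from the ring atom that bears a large group; the step is an at least 32-fold lower number from compound 2 to compound 4 (1.51 log units; beyond the scatter), so a change on the ring alone can move the number by a large step. Against the group of compound 1 the whole replacement gives an at least 150-fold lower number from compound 1 to compound 4 (2.18 log units; beyond the scatter), while an at least 2.0-fold lower number from compound 3 to compound 4 (0.30 log units; that floor lies within the scatter) cannot be read, its floor lying within the scatter.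

On these data alone, what a methyl, a hydroxyl or an amine would do on that same ring carbon stays open. As far as these compounds go, how far compound 4 actually lies under its limit also stays open.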